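Carbamate-bearing chain added to the sulfonyl carbon of compound 3

A few compounds are considered here, and "the series" means these few. Any claim that something is new, unique, unknown or untested is made for them only; others in the source may bear on it.

Among the measured compounds shown here, in an ADME assay on microsomes from liver (Homo sapiens) for metabolic stability, with a stated time of 10 min (on this read-out higher numbers stand for a more stable compound and lower numbers for a less stable compound), compound 3 `CS(=O)(=O)NC(=O)c1ccc(Nc2nc(NC3(c4ccc(Cl)cc4)CC3)nc(OCC(F)(F)F)n2)cc1` gives 100%; no other compound of the three stands beyond the scatter above it. Compound 2 `O=C(NS(=O)(=O)CCNCc1ccccc1)c1ccc(Nc2nc(NC3(c4ccc(Cl)cc4)CC3)nc(OCC(F)(F)F)n2)cc1` gives 99%, and compound 1 `CC(C)C(=O)NCCS(=O)(=O)NC(=O)c1ccc(Nc2nc(NC3(c4ccc(Cl)cc4)CC3)nc(OCC(F)(F)F)n2)cc1` gives 86%. The step of a number 1 percentage points higher from compound 2 to compound 3 (within the scatter) lies within the scatter, whereas a number 14 percentage points higher from compound 1 to compound 3 (beyond the scatter) and a number 13 percentage points higher from compound 1 to compound 2 (beyond the scatter) lie beyond it. Compound 4 `COC(=O)NCCS(=O)(=O)NC(=O)c1ccc(Nc2nc(NC3(c4ccc(Cl)cc4)CC3)nc(OCC(F)(F)F)n2)cc1` differs from compound 3 by ((methoxycarbonyl)amino)methyl in place of hydrogen on a saturated chain carbon bound to a sulfonyl sulfur. For the measured compounds named here, two measured steps bear on this change, both at the same place on the chain: a number 14 percentage points higher from compound 1 to compound 3 (beyond the scatter), where the chain carries an isopropylcarbonyl amide, and a number 1 percentage points higher from compound 2 to compound 3 (within the scatter), where it carries a benzylamine. The methoxycarbonyl carbamate of compound 4 resembles the amide of compound 1 more than the benzylamine of compound 2, so the expectation for compound 4 is a modest loss against compound 3, possibly within the scatter. Compound 4 is therefore estimated at 92%, between 78% and 100%. The step of a number 8 percentage points lower from compound 3 to compound 4 (within the scatter) is the expected decrease.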

Compound 4, percent of the compound remaining: 90%
Estimate against measurement, compound 4: 2 percentage points above; the measured number falls inside the stated range.
By their numbers in this assay, from the lowest: compounds 1, 4, 2 and 3 (each within the scatter of the next, the first and the last beyond it).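

In this assay the step of a number 10 percentage points lower from compound 3 to compound 4 (within the scatter) shows that this saturated chain carbon bound to a sulfonyl sulfur can carry ((methoxycarbonyl)amino)methyl without leaving the scatter of compound 3, a separation that the isopropylcarbonyl amide chain of compound 1 did cross. Changes further out on the chain cannot be told apart either: the step of a number 9 percentage points lower from compound 2 to compound 4 (within the scatter) for methoxycarbonyl in place of benzyl on the amine nitrogen and the step of a number 4 percentage points higher from compound 1 to compound 4 (within the scatter) for methoxy in place of isopropyl on the carbonyl carbon both stay within the scatter. No evidence at hand explains these numbers.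

Going by these compounds, whether a urea or a longer chain at this place would stay as close to compound 3 remains open. So does the effect of a free primary amine or a carboxylic acid there.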